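The compounds below may be only part of what the source reports. "The series", "measured", "known", "first", "only" and "open" are said of these compounds alone.

Measured compounds in an assay for inhibition of Polyunsaturated fatty acid 5-lipoxygenase (Homo sapiens), read by spectrophotometry, tested at 10 uM, in the presence of a further agent that is not named here; on this read-out lower numbers stand for less inhibition and higher numbers for more inhibition at the one concentration tested (going by the name of the read-out):

compound 1, `Cc1nc(NC(=O)c2ccccc2)sc1C(=O)/C=C/c1ccc(F)cc1`: 98%
compound 2, `COc1ccc(C(=O)Nc2nc(C)c(C(=O)/C=C/c3ccc(F)cc3)s2)cc1`: 88.2%
compound 3, `COc1ccc(/C=C/C(=O)c2sc(NC(=O)c3ccccc3)nc2C)cc1OC`: 70.2%

Compound 1 and compound 2 share one core and differ in one place, (methoxy in place of hydrogen on an aromatic carbon), on an aromatic carbon of a six-membered aromatic ring of carbon only, para to a large group. That single change gives a number 9.8 percentage points lower from compound 1 to compound 2 (within the scatter), a step within the scatter. Compound 3 carries a different core; the difference between the core of compound 3 and the core of compound 1 is not broken down here. Its value in this assay is the lowest of the three, and the gaps to compound 2 and compound 1 are both beyond the scatter.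

Compound 4, `COc1cc(/C=C/C(=O)c2sc(NC(=O)c3ccccc3)nc2C)cc(OC)c1OC`, is not yet measured. From compound 3 it differs by methoxy in place of hydrogen on an aromatic carbon, the same kind of change as from compound 1 to compound 2, but at a different place: here ortho to a methoxy group, meta to a large group and meta to a methoxy group, rather than para to a large group. Among the measured compounds shown here, the only measured example of adding a methoxy is a number 9.8 percentage points lower from compound 1 to compound 2 (within the scatter), a small step, so for compound 4 a comparably small step is expected, a number 8.2 percentage points lower from compound 3 to compound 4 (within the scatter). Compound 4 is estimated at 62%, with a range from 42% to 80%, resting on compound 3 at 70.2% and on the small step seen from compound 1 to compound 2.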

Compound 4, a percentage reported as inhibition, at one concentration (the size of the read-out at that concentration, not a potency): 100%
Compound 4: middle estimate off by 38 percentage points, on the low side; the whole stated range lies below it.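

In this assay the new methoxy gives a number 29.8 percentage points higher from compound 3 to compound 4 (beyond the scatter) and so does not repeat the step seen on the other core, showing that this change does not carry over at a fixed size between the two cores: the same change on two cores in this assay, a number 9.8 percentage points lower (within the scatter) from compound 1 to compound 2 and a number 29.8 percentage points higher (beyond the scatter) from compound 3 to compound 4, 39.6 percentage points apart, beyond the scatter of two such steps. The two methoxy groups also stand at different places, para to a large group in compound 2 and, in compound 4, ortho to a methoxy group, meta to a large group and meta to a methoxy group, so these pairs do not separate the effect of the core from that of the position. Among the compounds shown here, with a single step on each core, this shows only that the earlier step cannot be transferred here; it gives no rule for either core and no reason for the difference.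

Still open, as far as these compounds go, is whether methoxy at the place changed in compound 4 would give a like step on the core of compound 1. Also open, from the compounds shown here alone, is how a different group at that place, such as a hydroxyl, an amine or a carboxylic acid, would compare with methoxy.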